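Replacing trifluoromethyl with fluoro on the shared core

The source may report more compounds than this note shows. Statements on the series, on what has been measured and on what is new or still open speak of the compounds shown alone.

In a functional assay on MCF7 cells (Homo sapiens) for inhibition, read by MTT assay, with a stated time of 72 h (on this read-out higher numbers stand for weaker inhibition and lower numbers for stronger inhibition), compound 1 (`Cc1ccc(NC(=O)C2CCN(C/C=C/c3ccccc3)CC2)cc1`) gives 30000 nM and compound 2 (`COc1cccc(NC(=O)C2CCN(C/C=C/c3ccccc3)CC2)c1`) gives 42700 nM while compound 3 (`O=C(Nc1cccc(C(F)(F)F)c1)C1CCN(C/C=C/c2ccccc2)CC1`) gives 16100 nM on the same read-out. Compound 3 therefore stands within the scatter of compound 1 but apart from compound 2, as the measured change shows (a 2.7-fold lower number from compound 2 to compound 3 (0.42 log units; beyond the scatter)). Compound 4 (`O=C(Nc1cccc(F)c1)C1CCN(C/C=C/c2ccccc2)CC1`) carries fluoro in place of trifluoromethyl on an aromatic carbon, meta to a large group (fluoro in place of trifluoromethyl on an aromatic carbon). Among the compounds with values here, two measured steps bear on this change. The closer one is the exchange of methoxy for trifluoromethyl already cited, which was modest. The other, which changes the aromatic group more broadly, stayed within the scatter (a 1.4-fold higher number from compound 1 to compound 2 (0.15 log units; within the scatter)). Within the data shown here, no fluoro compound has been measured, so the series offers no direct precedent. A step no larger than modest is therefore expected, most likely none beyond the scatter, with a slight lean towards a higher number (a 1.6-fold higher number from compound 3 to compound 4 (0.21 log units; within the scatter)). For compound 4 the estimated value is 26000 nM with an expected range from 12000 nM to 50000 nM in this assay when measured.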

Compound 4, half-maximal inhibitory concentration: 33000 nM
The estimate for compound 4 lay 1.3-fold (0.10 log units) below the measured number, and the stated range covers the measured number.
By their numbers in this assay, from the lowest: compounds 3, 1, 4 and 2 (each within the scatter of the next, the first and the last beyond it).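

In this assay, fluoro in place of trifluoromethyl on this aromatic carbon gives a modest step beyond the scatter (a 2.0-fold higher number from compound 3 to compound 4 (0.31 log units; beyond the scatter)), so this position does respond to an exchange between two fluorine-bearing groups. Fluoro in place of methoxy stays within the scatter (a 1.3-fold lower number from compound 2 to compound 4 (0.11 log units; within the scatter)), and so does the wider change of the aromatic group (a 1.1-fold higher number from compound 1 to compound 4 (0.04 log units; within the scatter)), which leaves compounds 1, 2 and 4 unseparated; compound 3 stands apart from compounds 2 and 4, but compound 1 goes against any clean split, as it lies within the scatter of compound 3. No measurement at hand explains why trifluoromethyl differs from fluoro here. The compounds shown leave open where a chloro group, a nitrile or an amine on this aromatic carbon would fall. They also leave open whether the step from trifluoromethyl to fluoro would hold on another aromatic carbon of the ring.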